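Bromo in Place of Fluoro: A Single Expected Step

The compounds below may be only part of what the source reports. "The series", "measured", "known", "first", "only" and "open" are said of these compounds alone.

Three compounds were tested in an in vitro assay on P815B cells for inhibition of Indoleamine 2,3-dioxygenase 1 (Mus musculus), tested at 20 uM; a higher number here means more inhibition at the concentration tested (going by the name of the read-out), a lower number less inhibition. Compound 1 `O=C(Cc1cccnc1)c1cc2c(Cl)cc(Cl)cc2[nH]1` is reported as "not active" (no number reported) in this assay. Compound 3 `O=C(Cc1ccncc1)c1cc2ccccc2[nH]1` likewise comes back as "not active" (no number reported) there. Compound 2 `O=C(Cc1cccnc1)c1cc2cc(F)ccc2[nH]1` is the only one of the three with a figure: in this assay compound 2 gives 24%. On the numbers shown, compound 2 therefore stands alone; the other two entries carry no number to set beside it, so no ordering among the three can be drawn.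

Compound 4 `O=C(Cc1cccnc1)c1cc2cc(Br)ccc2[nH]1` has not yet been measured in this assay. It differs from compound 2 in one place: bromo in place of fluoro on an aromatic carbon. Among the compounds with values here, no pair of measured compounds differing in a single place is available, so the size of such a change cannot be read from the data. Within the data shown here, with only one number among the measured compounds and no comparable step, the expectation for compound 4 rests on compound 2 alone, and the move from the fluoro compound to the bromo compound is expected to stay within the usual scatter, in no clear direction.

On that basis compound 4 is expected to give about 27% in this assay, within a range from 10% to 45%. The step is estimated at a number 3 percentage points higher from compound 2 to compound 4 (within the scatter), which is no change beyond the scatter.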

Compound 4, a percentage reported as inhibition, at one concentration (the size of the read-out at that concentration, not a potency): "not active" (no number reported)
Compound 4: no number reported; there is nothing to compare the estimate with.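

In this assay, within the data shown here, compound 4 gives "not active" (no number reported) and compound 2 gives 24%, so no step between these two compounds can be read. No evidence is available that bears on this result. The compounds shown leave open how bromo in place of fluoro on this aromatic carbon alters inhibition.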